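This account rests on a few compounds, and the source may have more. Where it says the series, first, only, none or still open, it means among the compounds named here.

Compound 1 `CCOc1ccc(-n2nnc3n[nH]c(NC)c3c2=O)cc1` gives in an ADME assay on TERT-RPE1 cells (Homo sapiens) for cytotoxicity, read by resazurin assay, with a stated time of 48 h (on this read-out higher numbers stand for weaker inhibition and lower numbers for stronger inhibition), only a limit of the assay, > 100000 nM.
Compound 2 `CCOc1ccc(NC(=O)CC#N)cc1` gives in this assay likewise only a limit, > 100000 nM.
Compound 3 `CCOc1ccc(-n2nnc3n[nH]c(Nc4ccccc4)c3c2=O)cc1` gives in this assay again only a limit, > 100000 nM.

Compound 3 thus stands nowhere in particular on the numbers shown: its value is a limit, and the two other values are limits as well, all sitting at the limit of > 100000 nM in this assay, at which 3 of the 3 values shown sit. Going by the values given here, the single measured step that bears on the change to come, a step that the two limits leave unreadable from compound 1 to compound 3, has no readable size, its two ends being limits.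

Compound 4 `C=CCNc1[nH]nc2nnn(-c3ccc(OCC)cc3)c(=O)c12` differs from compound 3 in one place: allyl in place of phenyl on a nitrogen on an aromatic ring. No measured step tells how large such a change is in this assay; the shown values say only that compound 1, compound 2 and compound 3 each reach (the limit of > 100000 nM in this assay, at which 3 of the 3 values shown sit). On that basis no step beyond the scatter is expected in this assay, and compound 4 is estimated at 150000 nM, with a range of 50000 nM to 500000 nM. The expected step is a step that the limit leaves unreadable from compound 3 to compound 4, that is, none beyond the scatter.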

Compound 4, half-maximal inhibitory concentration: > 100000 nM
Compound 4 ended at the assay's limit; the forecaster's own chance of this, stated with the estimate: 85%; the middle value does not contradict the limit.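

Compound 4 gives only a limit in this assay, > 100000 nM, so neither its step from compound 3 nor its step from compound 1 can be read. The compounds shown leave open whether any change at this place would give a measurable value: the limit of > 100000 nM in this assay, at which 4 of the 4 values shown sit.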